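A few compounds are considered here, and "the series" means these few. Any claim that something is new, unique, unknown or untested is made for them only; others in the source may bear on it.

Going by the values given here, compound 1 `O=C(O)c1ccc(-c2cnc(C(=O)CCc3ccc(-c4ccccc4)cc3)o2)nc1` carries the 5-carboxypyridin-2-yl group on the shared core; in an assay for inhibition of Fatty-acid amide hydrolase 1 (Rattus norvegicus) (on this read-out lower numbers stand for stronger inhibition and higher numbers for weaker inhibition), compound 1 gives 14 nM, the highest of the two numbers measured so far. Among the compounds with values here, compound 2 `O=C(O)c1ccc(-c2cnc(C(=O)CCc3ccc(COc4ccccc4)cc3)o2)nc1` differs from compound 1 in a single place, and in this assay compound 2 gives 4.6 nM; the step of a 3.0-fold lower number from compound 1 to compound 2 (0.48 log units; beyond the scatter) is the only measured step. Within the data shown here, compound 3 `COC(=O)c1cccc(-c2cnc(C(=O)CCc3ccc(-c4ccccc4)cc3)o2)n1` has not been measured. 6-(methoxycarbonyl)pyridin-2-yl in place of 5-carboxypyridin-2-yl on an aromatic carbon This change and the one measured step sit at different places in the structure, so no measured step bears on it, and neither its direction nor its size can be read from the numbers at hand. Compound 3 is expected to give 40 nM in this assay, with a range from 8 nM to 200 nM. The step of a 2.9-fold higher number from compound 1 to compound 3 (0.46 log units; beyond the scatter) is therefore an estimate with wide uncertainty rather than a projection from data.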

Compound 3, inhibition constant: 1.2 nM
Compound 3: the middle estimate sits 33-fold (1.52 log units) above what was measured; the measured number lies below the stated range.
By their numbers in this assay, from the lowest: compound 3; then compound 2; then compound 1.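

Going by these compounds alone, the only earlier step lay at a different place in the structure, so this is the first reading at the aromatic carbon next to the ring oxygen: in this assay, 6-(methoxycarbonyl)pyridin-2-yl in place of 5-carboxypyridin-2-yl gives a 12-fold lower number from compound 1 to compound 3 (1.07 log units; beyond the scatter). The step is large and beyond the scatter, so among the compounds shown, the 5-carboxypyridin-2-yl group is not required for a low number at this position. Nothing at hand accounts for the size or direction of this step.

Going by these compounds, the change swaps the carboxylic acid for a methyl ester and also moves the substituent from the 5 to the 6 position of the pyridin-2-yl group, so the share of each remains open. The 6-carboxypyridin-2-yl and 5-(methoxycarbonyl)pyridin-2-yl groups would separate the two, and a primary amide would extend the comparison.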